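Swapping Hydroxy for Amino on a Stilbene Scaffold

The compounds below may be only part of what the source reports. "The series", "measured", "known", "first", "only" and "open" are said of these compounds alone.

Of the compounds shown here, three of a shared core have been tested in an ADME assay on HEK293 cells (Homo sapiens) for inhibition, read by MTT assay, with a stated time of 2 days; on this read-out higher numbers stand for weaker inhibition and lower numbers for stronger inhibition. Compound 1, `Oc1cccc(/C=C/c2ccccc2O)c1`, gives 18 ug/mL in this assay. Compound 2, `Nc1ccccc1/C=C/c1cccc(O)c1`, gives 20 ug/mL. These two differ by a single change, (amino in place of hydroxy on an aromatic carbon), and the step of a 1.1-fold higher number from compound 1 to compound 2 (0.05 log units; within the scatter) shows that this swap left the read-out essentially unchanged. Compound 3, `COc1ccccc1/C=C/c1ccc(O)cc1`, gives 41 ug/mL, the highest of the three numbers, which on this read-out means it inhibits more weakly than compound 1 and compound 2. How the core of compound 3 differs from that of compound 1 is not broken down here.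

Compound 4, `COc1ccccc1/C=C/c1ccc(N)cc1`, has not yet been measured. Its difference from compound 3 is amino in place of hydroxy on an aromatic carbon. For the measured compounds named here, this is the same kind of change as the one from compound 1 to compound 2, though not the same: in compound 2 the new group sits ortho to a group of 9 heavy atoms, whereas in compound 4 it sits para to a large group. Because the earlier step of a 1.1-fold higher number from compound 1 to compound 2 (0.05 log units; within the scatter) stayed within the scatter, the step of a 1.1-fold higher number from compound 3 to compound 4 (0.03 log units; within the scatter) is also expected to be small. Going by the values given here, with only one prior example of this swap, the expectation carries real uncertainty. Compound 4 is therefore estimated at 44 ug/mL, with a likely range from 22 ug/mL to 90 ug/mL.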

Compound 4, half-maximal inhibitory concentration: 1 ug/mL
Beside the measured number, compound 4's estimate is 44-fold (1.64 log units) above it; the measured number lies below the stated range.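

On the core of compound 3, amino in place of hydroxy gave a 41-fold lower number from compound 3 to compound 4 (1.61 log units; beyond the scatter) in this assay, so a single swap turned a weak inhibitor into a much stronger one on this read-out. The size of this swap therefore did not carry over from one core to the other, and a small step on one core gave no safe guide to the step on another: the same change on two cores in this assay, a 1.1-fold higher number (0.05 log units; within the scatter) from compound 1 to compound 2 and a 41-fold lower number (1.61 log units; beyond the scatter) from compound 3 to compound 4, 46-fold (1.66 log units) apart, beyond the scatter of two such steps What this does not show is the reason for the gap, as two examples cannot separate the role of where the swap sits on the ring from the role of the rest of the core, and they cannot show whether either step is typical of the series.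

The compounds shown leave open whether the strong result on this core belongs to amino alone, or would also appear with another group in the same place, such as methylamino, fluorine or a carboxylic acid. They also leave open whether the large step would persist if the methoxy group elsewhere on the core of compound 4 were replaced by a longer chain such as ethoxy.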